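A few compounds are considered here, and "the series" means these few. Any claim that something is new, unique, unknown or untested is made for them only; others in the source may bear on it.

Going by the values given here, the three compounds measured so far share one core, bearing a long unsaturated ester chain and a phosphoserine head, and differ only in the small group on the middle carbon. In an assay on HEK293 cells for agonist activity at probable G-protein coupled receptor 34 (Mus musculus), with a stated time of 1 h (on this read-out lower numbers stand for smaller maximal responses and higher numbers for larger maximal responses), compound 1 `CCCCCCCC/C=C\CCCCCCCC(=O)O[C@H](C)COP(=O)(O)OC[C@H](N)C(=O)O` gives 6.1%. Compound 2 `CCCCCCCC/C=C\CCCCCCCC(=O)OC[C@@H](COC)OP(=O)(O)OC[C@H](N)C(=O)O` gives 12.9% in this assay, and compound 3 `CCCCCCCC/C=C\CCCCCCCC(=O)OC[C@H](COC)OP(=O)(O)OC[C@H](N)C(=O)O` gives 7.5%. Compound 2 thus carries the larger of the three numbers, yet neither neighbour separates from it: the step of a number 5.4 percentage points lower from compound 2 to compound 3 (within the scatter) stays within the scatter, and the gap to compound 1 is of the same kind. The change between compounds 2 and 3 touches only the drawing of one stereocentre (the fact that one of compounds 2 and 3 is drawn with a defined configuration and the other without, at the place where they differ), so the pair says nothing about substituent size.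

Compound 4 `CCCCCCCC/C=C\CCCCCCCC(=O)OC[C@@H](COCc1ccccc1)OP(=O)(O)OC[C@H](N)C(=O)O` awaits measurement. It differs from compound 2 by phenyl in place of hydrogen on a saturated chain carbon bound to an oxygen on a saturated carbon. Among the compounds with values here, no measured step alters this part of the molecule; the single measured step, a number 5.4 percentage points lower from compound 2 to compound 3 (within the scatter), concerns a stereocentre and lies within the scatter. The account therefore expects no step beyond the scatter, a change of about a number 1.1 percentage points higher from compound 2 to compound 4 (within the scatter). Compound 4 is estimated to give 14% in this assay, with a range from 4% to 30%, pending the measurement.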

Compound 4, largest response reached (Emax), in percent of the reference or control that the assay uses: 9.6%
Compound 4: middle estimate off by 4.4 percentage points, on the high side, within the range that was stated.
By their numbers in this assay, from the lowest: compounds 1, 3, 4 and 2 (each within the scatter of the next).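

The first change measured at this position, from methoxy to benzyloxy, gives in this assay a number 3.3 percentage points lower from compound 2 to compound 4 (within the scatter). Adding phenyl in place of hydrogen on a saturated chain carbon bound to an oxygen on a saturated carbon, with its six-membered aromatic ring of six heavy atoms, therefore produces no step that the read-out can separate from the scatter, so this one change shows no dependence of the maximal response on the size of the group at this place. Nothing available bears on why the step is as it is.

What the compounds shown leave open is whether an amine or a carboxylic acid at the end of the methoxymethyl group, or a longer alkyl chain on its oxygen, would give a step beyond the scatter at this position. Also open, as far as these compounds go, is whether the (benzyloxy)methyl group drawn with the other configuration at the stereocentre would give a change of a different size from the one seen with the methoxymethyl group, a number 5.4 percentage points lower from compound 2 to compound 3 (within the scatter).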